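A few compounds are considered here, and "the series" means these few. Any claim that something is new, unique, unknown or untested is made for them only; others in the source may bear on it.

Measured so far:
compound 1 `COC(=O)/C=C/c1cccc(N(Cc2ccc(/C=C/c3c(Cl)cccc3Cl)cc2)C(=O)C(C)C)c1`: 195 nM
compound 2 `COC(=O)/C=C/c1cccc(N(Cc2ccc(/C=C/c3ccccc3F)cc2)C(=O)NC(C)C)c1`: 431 nM

In an assay on isolated protein with Bile acid receptor (Homo sapiens) as the target (on this read-out higher numbers stand for an effect only at larger amounts of compound and lower numbers for an effect already at smaller amounts), compound 1 gives 195 nM, the lowest of the two numbers. Compound 2 gives 431 nM, a higher number, beyond the scatter. Within the data shown here, the two differ in more than one place, so no single step joins them. Compound 3 `COC(=O)/C=C/c1cccc(N(Cc2ccc(/C=C/c3scnc3C)cc2)C(=O)C(C)C)c1` is not yet measured. Relative to compound 1 it carries 4-methyl-1,3-thiazol-5-yl in place of 2,6-dichlorophenyl on a double-bonded chain carbon bound to a double-bonded chain carbon. Among the measured compounds shown here, no measured pair shows this exchange, so the step is estimated without a precedent: a shift toward higher numbers, beyond the scatter, is expected, of the size a 3.1-fold higher number from compound 1 to compound 3 (0.49 log units; beyond the scatter). Compound 3 is expected near 600 nM, within a range from 150 nM to 2500 nM.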

Compound 3, half-maximal effective concentration: 228 nM
For compound 3 the middle estimate is 2.6-fold (0.42 log units) above the measured one, and the stated range covers the measured number.
By their numbers in this assay, from the lowest: compounds 1, 3 and 2 (each within the scatter of the next, the first and the last beyond it).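

In this assay the place on a double-bonded chain carbon bound to a double-bonded chain carbon accepts 4-methyl-1,3-thiazol-5-yl in place of 2,6-dichlorophenyl with a 1.2-fold higher number from compound 1 to compound 3 (0.07 log units; within the scatter), a step within the scatter. In this one pair, a five-membered aromatic ring with 2 hetero atoms and no chlorine therefore gives a number indistinguishable from that of the six-membered carbon ring. Nothing at hand explains this. Open, as far as these compounds go, is whether a pyridine ring or an unsubstituted phenyl at this place, or a carboxylic acid in place of the methyl ester, would keep the number in this range.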